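Phenyl in Place of Thiophen-2-yl: Expected Cytotoxicity

The compounds below may be only part of what the source reports. "The series", "measured", "known", "first", "only" and "open" are said of these compounds alone.

Compound 1 `O=C(/C=C/c1ccco1)c1ccc(NC(=O)c2ccccc2)cc1` gives > 100000 nM in a toxicity assay on FHC cells (Homo sapiens) for cytotoxicity, read by resazurin assay, with a stated time of 48 h (a higher number here means that more compound is tolerated, a lower number that less compound is tolerated), a limit of the assay rather than a number.
Compound 2 `Nc1ccc(C(=O)/C=C/c2ccccc2)cc1` gives > 100000 nM in this assay, again only a limit.
Compound 3 `O=C(/C=C/c1ccccc1)c1ccc(NC(=O)c2cccs2)cc1` gives 83000 nM in this assay.

Within the data shown here, compound 3 therefore stands as the only compound of the three with a measured number; the other two are limits, as the evidence that the limit of > 100000 nM in this assay, at which 2 of the 3 values shown sit, shows. Among the measured compounds shown here, the single measured step runs from the free amine to the amide: an at least 1.2-fold lower number from compound 2 to compound 3 (0.08 log units; that floor lies within the scatter), a floor that lies within the scatter, so no real change was seen on adding the (thiophen-2-yl)carbonyl group.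

Compound 4 `O=C(/C=C/c1ccccc1)c1ccc(NC(=O)c2ccccc2)cc1` is the benzoyl counterpart of compound 3, differing by phenyl in place of thiophen-2-yl on a carbonyl carbon. For the measured compounds named here, no measured step exchanges thiophen-2-yl for phenyl on this carbonyl carbon, so nothing in the measured pairs speaks directly to it. Going by the values given here, compound 1, which carries the same benzoyl amide on a furan-bearing core, sits at the limit of this assay with > 100000 nM, and the one measured step was within the scatter. The expected step is therefore a 1.2-fold higher number from compound 3 to compound 4 (0.08 log units; within the scatter), none beyond the scatter. Compound 4 is estimated at 100000 nM, within 40000 nM to 250000 nM, with a fair chance that only a limit is reported.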

Compound 4, half-maximal cytotoxic concentration: 73000 nM
Compound 4: the middle estimate sits 1.4-fold (0.14 log units) above what was measured; the measured number falls inside the stated range.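

Among these compounds, compound 3 and compound 4 give the first pair of measured numbers at this carbonyl carbon, whose other neighbour is an amide-type nitrogen. In this assay, phenyl in place of thiophen-2-yl gives a 1.1-fold lower number from compound 3 to compound 4 (0.06 log units; within the scatter), so exchanging a five-membered aromatic ring with 1 hetero atom for a six-membered aromatic ring of carbon only shows no real difference at this place. The other two steps, an at least 1.3-fold lower number from compound 2 to compound 4 (0.13 log units; that floor lies within the scatter) and an at least 1.3-fold lower number from compound 1 to compound 4 (0.13 log units; that floor lies within the scatter), add only floors, and the true size of each stays unknown, as compound 1 and compound 2 are limits and not numbers: the limit of > 100000 nM in this assay, at which 2 of the 4 values shown sit.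

From the compounds shown here alone, what remains open is whether a group of another kind on this carbonyl carbon, such as a cyclohexyl ring, a pyridine ring or a longer alkyl chain, would give a step beyond the scatter. Going by these compounds, it is equally open whether an amine or a carboxylic acid on the phenyl ring of the benzoyl group would move the number away from those of compound 3 and compound 4.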